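Tolerance in HEL Cells: Swapping Bromo for Nitro

The source may hold more compounds than are shown below. What is called first, only, known or untested is meant among the compounds shown, and "the series" means these compounds.

Compound 1 `O=C(COc1cccc2ccccc12)N/N=C/c1ccc(O)cc1` gives 20 ug/mL in an ADME assay on HEL cells (Homo sapiens) for cytotoxicity; a higher number here means that more compound is tolerated, a lower number that less compound is tolerated.
Compound 2 `O=C(COc1cccc2ccccc12)N/N=C/c1ccccc1Br` gives only a limit of this assay, >= 20 ug/mL.
Compound 3 `O=C(COc1cccc2ccccc12)N/N=C/c1cccc(Br)c1` gives 100 ug/mL.

Compound 2 thus stands at a limit, its number bounded but not read. From compound 1 the step is a number no lower from compound 1 to compound 2 (the limit leaves the size open), and onward a step that the limit leaves unreadable from compound 2 to compound 3. Compound 3 sits apart from compound 1 by a 5.0-fold higher number from compound 1 to compound 3 (0.70 log units; beyond the scatter). The unmeasured compound 4 `O=C(COc1cccc2ccccc12)N/N=C/c1ccccc1[N+](=O)[O-]` differs from compound 2 as follows: nitro in place of bromo on an aromatic carbon. Going by the values given here, no measured step exchanges bromo for nitro, so none bears directly on this change, and both steps touching compound 2 are unreadable because of the limit of >= 20 ug/mL in this assay, at which 1 of the 3 values shown sits. The spread between compound 1 and compound 3 frames what is plausible. Compound 4 is expected to show a step that the limit leaves unreadable from compound 2 to compound 4. The estimate for compound 4 is 50 ug/mL, within 20 ug/mL to 100 ug/mL.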

Compound 4, minimum cytotoxic concentration: 20 ug/mL
Compound 4: the middle estimate sits 2.5-fold (0.40 log units) above what was measured; the measured number falls inside the stated range.
By their numbers in this assay, from the lowest: compounds 1 and 4 (each within the scatter of the next); then compound 3.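

With nitro in place of bromo on this aromatic carbon, the position now has a readable number where compound 2 offered none: in this assay, compound 4 gives 20 ug/mL. Compound 2 holds only a limit, >= 20 ug/mL. The change gives a number no higher from compound 2 to compound 4 (the limit leaves the size open), and neither this step nor the others touching compound 2 can be read for size: the limit of >= 20 ug/mL in this assay, at which 1 of the 4 values shown sits.

Going by these compounds, how far bromo and nitro truly differ on this carbon stays open. So does how an amine or a carboxylic acid on the same aromatic carbon would read in this assay.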